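This account rests on a few compounds, and the source may have more. Where it says the series, first, only, none or still open, it means among the compounds named here.

Measured compounds:
Compound 1, `Cc1sc2nc(NC(=O)CCCc3ccccc3)sc(=O)c2c1C`: in an assay on CHO cells for displacement of a labelled ligand from adenosine receptor A2b (Homo sapiens), read by scintillation counting, with a stated time of 75 min (on this read-out higher numbers stand for weaker inhibition and lower numbers for stronger inhibition), compound 1 gives only a limit, > 1000 nM.
Compound 2, `COc1cccc(/C=C/C(=O)Nc2nc3ccccc3c(=O)s2)c1`: in this assay compound 2 gives 679 nM.
Compound 3, `COc1cccc(/C=C/CC(=O)Nc2nc3ccccc3c(=O)s2)c1`: in this assay compound 3 gives only a limit, >= 1000 nM.

Compound 3 stands at the limit of >= 1000 nM in this assay, at which 1 of the 3 values shown sits, so for it only a limit and no number is known. Compound 1 stands at another such limit, (the limit of > 1000 nM in this assay, at which 1 of the 3 values shown sits). Among the compounds with values here, of the three measured compounds only compound 2 has a numerical value, and there is no pair of measured compounds differing in a single place, so no measured step can guide the next one.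

Compound 4, `O=C(C/C=C/c1ccccc1)Nc1nc2ccccc2c(=O)s1`, has not yet been measured. It differs from compound 3 by hydrogen in place of methoxy on an aromatic carbon. Without a measured step to lean on, the expected change in this assay is small, not beyond the usual scatter, and in no clear direction. The estimated step is a step that the limit leaves unreadable from compound 3 to compound 4. Compound 4 is therefore expected to give about 1500 nM, with a range from 600 nM to 4000 nM, and a fair chance that the assay again reports only a limit.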

Compound 4, inhibition constant: 119 nM
The estimate for compound 4 lay 13-fold (1.10 log units) above the measured number, and the stated range ends above it.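

At this place on the six-membered aromatic ring, what the ring carries clearly matters: going from 3-methoxyphenyl to phenyl gives an at least 8.4-fold lower number from compound 3 to compound 4 (0.92 log units; beyond the scatter) in this assay, the first measured step among these compounds and one beyond the scatter. Compound 3 gives only a limit, >= 1000 nM. The step is therefore a minimum, and its full size cannot be read: the limit of >= 1000 nM in this assay, at which 1 of the 4 values shown sits.

Going by these compounds, whether a hydroxyl, a chlorine or an amine at this same place would keep the lower number remains open. On these data alone, it is also open whether hydrogen in place of methoxy would act in the same way on the chain of compound 2, which carries the same 3-methoxyphenyl group and gives 679 nM in this assay.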